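Benzyl in place of benzyloxy: compound 4

The compounds below may be only part of what the source reports. "The series", "measured", "known", "first", "only" and "open" are said of these compounds alone.

Values so far in an ADME assay on THP-1 cells (Homo sapiens) for cytotoxicity, read by trypan blue exclusion, with a stated time of 48 h (a lower number here means a stronger inhibitor of growth, a higher number a weaker inhibitor of growth), for the series:
- compound 1 `Cc1cc(CNCc2ccc(F)cc2)c(C)n1-c1ccc(Cl)cc1` gives 8.4 ug/mL
- compound 2 `Cc1cc(CNCc2ccc(Cl)cc2)c(C)n1-c1ccc(Cl)cc1` gives 18 ug/mL
- compound 3 `Cc1cc(CNOCc2ccccc2)c(C)n1-c1ccc(Cl)cc1` gives 67 ug/mL

Compound 3 has the highest number of the three, and its gaps to compound 1 and compound 2 are both beyond the scatter. Compound 4 `Cc1cc(CNCc2ccccc2)c(C)n1-c1ccc(Cl)cc1` has benzyl in place of benzyloxy on an amine nitrogen.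

For the measured compounds named here, two measured steps bear most directly on this change: an 8.0-fold higher number from compound 1 to compound 3 (0.90 log units; beyond the scatter) and a 3.7-fold higher number from compound 2 to compound 3 (0.57 log units; beyond the scatter) are both modest, and each replaces a substituted benzyl with benzyloxy. Compound 4 reverses that type of change, but with an unsubstituted benzyl, for which no measurement exists. The swap of fluoro for chloro alone gives a 2.1-fold higher number from compound 1 to compound 2 (0.33 log units; beyond the scatter) as a modest step, so the ring substituent also matters and the range stays wide.

A lower number is therefore expected, of similar size to those two steps, with a 4.5-fold lower number from compound 3 to compound 4 (0.65 log units; beyond the scatter) as the estimated step. For compound 4 the estimated value is 15 ug/mL with an expected range of 6 ug/mL to 40 ug/mL in this assay when measured.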

Compound 4, concentration for 50% growth inhibition: 7.2 ug/mL
Beside the measured number, compound 4's estimate is 2.1-fold (0.32 log units) above it, within the range that was stated.
By their numbers in this assay, from the lowest: compounds 4 and 1 (each within the scatter of the next); then compound 2; then compound 3.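

With the ring unsubstituted on both sides, the exchange of benzyloxy for benzyl on the amine nitrogen can now be read as a single change in this assay, and it gives a 9.3-fold lower number from compound 3 to compound 4 (0.97 log units; beyond the scatter) with no halogen change alongside it. The unsubstituted benzyl also separates the two halogens: a 2.5-fold lower number from compound 2 to compound 4 (0.40 log units; beyond the scatter) lies beyond the scatter, whereas a 1.2-fold lower number from compound 1 to compound 4 (0.07 log units; within the scatter) lies within it, so only chloro is distinguishable from hydrogen on that aromatic carbon in this small set. Nothing measured here accounts for these differences.

Going by these compounds, it remains open whether the benzyloxy step keeps its size when the ring carries fluoro or chloro. Also open, on these data alone, is how methoxy or trifluoromethyl on that ring, or a longer chain in place of benzyl, would read in this assay against these values.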